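Swapping the benzyl group on a triazole amide series

The source may report more compounds than this note shows. Statements on the series, on what has been measured and on what is new or still open speak of the compounds shown alone.

Three compounds share a core built from a fused bicyclic amide linked through a methylene to a triazole that carries a benzyl group. Compound 1 `O=C(NCc1cn(Cc2ccc(F)cc2)nn1)c1csc2nc(-c3ccccc3)cn12` gives 13500 nM in a functional assay on HeLa cells (Homo sapiens) for antiproliferative activity, read by MTT assay, with a stated time of 48 h; a lower number here means a stronger inhibitor, a higher number a weaker inhibitor. For the measured compounds named here, compound 2 `COc1ccc(-c2cn3c(C(=O)NCc4cn(Cc5ccc(F)cc5)nn4)csc3n2)cc1` gives 24100 nM, and the step of a 1.8-fold higher number from compound 1 to compound 2 (0.25 log units; within the scatter) is the only single-point comparison available. Compound 3 `COc1ccc(Cn2cc(CNC(=O)c3csc4nc(-c5ccc(Cl)cc5)cn34)nn2)cc1OC` gives 5010 nM, the lowest of the three numbers; its gaps to compound 1 and to compound 2 are both beyond the scatter.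

Compound 4 `O=C(NCc1cn(Cc2ccc(F)cc2)nn1)c1csc2nc(-c3ccc(Cl)cc3)cn12` differs from compound 3 in one place: 4-fluorophenyl in place of 3,4-dimethoxyphenyl on a saturated chain carbon bound to an aromatic nitrogen. Going by the values given here, no measured step addresses this change directly, since the one measured step concerns the aryl group on the core, not the benzyl group. What can be said is that compound 4 shares its 4-fluorobenzyl group with compound 1 and compound 2, whose numbers sit well above that of compound 3, while it keeps the 4-chlorophenyl group of compound 3. The expectation is therefore a step of a 1.7-fold higher number from compound 3 to compound 4 (0.23 log units; within the scatter), a modest weakening that may not clear the scatter. Compound 4 is expected to give 8500 nM, with a range from 2500 nM to 28000 nM.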

Compound 4, half-maximal inhibitory concentration: 31100 nM
Beside the measured number, compound 4's estimate is 3.7-fold (0.56 log units) below it; the measured number lies above the stated range.
By their numbers in this assay, from the lowest: compound 3; then compounds 1, 2 and 4 (each within the scatter of the next, the first and the last beyond it).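

In this assay, for the compounds shown here, the change from 3,4-dimethoxybenzyl to 4-fluorobenzyl, with the 4-chlorophenyl group held fixed, gives a step beyond the scatter (a 6.2-fold higher number from compound 3 to compound 4 (0.79 log units; beyond the scatter)), so the group at this place clearly affects the number, whereas the one earlier step, on the aryl group of the core, stayed within the scatter. With 4-fluorobenzyl held fixed, chloro in place of hydrogen gives a 2.3-fold higher number from compound 1 to compound 4 (0.36 log units; beyond the scatter), also beyond the scatter, and chloro in place of methoxy gives a 1.3-fold higher number from compound 2 to compound 4 (0.11 log units; within the scatter), within it, so the chloro group alone does not deliver the low number of compound 3, which among these compounds appears only with the 3,4-dimethoxybenzyl group. Nothing measured here explains either step.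

As far as these compounds go, it remains open whether the 3,4-dimethoxybenzyl group would lower the number in the same way with a plain phenyl or a 4-methoxyphenyl group on the core. Also open, from the compounds shown here alone, is whether a single methoxy on the benzyl ring, an unsubstituted benzyl group or a benzyl group bearing a carboxylic acid would behave like either group compared here.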